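The source may report more compounds than this note shows. Statements on the series, on what has been measured and on what is new or still open speak of the compounds shown alone.

Measured compounds:
compound 1 `COc1c(/C=C/c2ccc(NS(C)(=O)=O)cc2)cc(N2CCC(=O)NC2=O)cc1C(C)(C)C`: 0.92 10^-6 cm/s
compound 2 `COc1c(C(=O)Nc2ccc(NS(C)(=O)=O)cc2)cc(N2CCC(=O)NC2=O)cc1C(C)(C)C`: 0.25 10^-6 cm/s
compound 3 `COc1c(NC(=O)c2ccc(NS(C)(=O)=O)cc2)cc(N2CCC(=O)NC2=O)cc1C(C)(C)C`: 0.22 10^-6 cm/s

The read-out throughout is a physicochemical assay for permeability, using PAMPA; on this read-out higher numbers stand for higher permeability and lower numbers for lower permeability. Compound 2 holds the second highest of the three numbers; compound 3 lies within the scatter of it, so no order between the two is drawn, while compound 1 stands beyond the scatter above both. Compound 4 `COc1c(C(=O)N(C)c2ccc(NS(C)(=O)=O)cc2)cc(N2CCC(=O)NC2=O)cc1C(C)(C)C` has not been measured in this assay. It differs from compound 2 in one place: methyl in place of hydrogen on an amide-type nitrogen. Going by the values given here, no measured pair shows this change, so its size cannot be read from the data at hand. The step of a 2.8-fold higher number from compound 2 to compound 4 (0.45 log units; beyond the scatter) is expected to be upward and to fall beyond the scatter, though not by a large margin. For compound 4 the value in this assay is estimated at 0.7 10^-6 cm/s, with a range from 0.3 10^-6 cm/s to 1.6 10^-6 cm/s.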

Compound 4, apparent permeability: 0.25 10^-6 cm/s
For compound 4 the middle estimate is 2.8-fold (0.45 log units) above the measured one; measured number below the stated range.
By their numbers in this assay, from the lowest: compounds 3, 2 and 4 (each within the scatter of the next); then compound 1.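

In this assay, methyl in place of hydrogen on an amide-type nitrogen gives no change at the digits printed from compound 2 to compound 4 (within the scatter). This single pair shows that, on this core, the amide hydrogen at this nitrogen can be replaced by methyl without a shift in the read-out beyond the scatter. Nothing at hand offers an explanation for this result.

Still open, on these data alone, is whether a longer chain such as ethyl, or a chain carrying an amine, on this nitrogen would read the same. Also open, as far as these compounds go, is whether methyl on the amide-type nitrogen of compound 3 would behave alike.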